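Chloro for bromo: from compound 2 to compound 4

This account rests on a few compounds, and the source may have more. Where it says the series, first, only, none or still open, it means among the compounds named here.

Of the compounds shown here, three have so far been tested in a functional assay on MCF7 cells (Homo sapiens) for cytotoxicity, with a stated time of 72 h; a lower number here means a stronger inhibitor, a higher number a weaker inhibitor. Compound 1 `C[C@@H](NC(=O)c1cc(Cl)ccc1O)C(=O)Nc1ccc(Cl)cc1` gives only a limit, > 20000 nM. Compound 3 `C[C@H](NC(=O)c1cc(Cl)ccc1O)C(=O)Nc1cccc(Cl)c1` likewise reaches only the limit of > 10000 nM. Compound 2 `CC(C)[C@H](NC(=O)c1ccc(Cl)cc1O)C(=O)Nc1ccc(Br)cc1` also stops at a limit, > 10000 nM. Compound 2 thus sits at the limit of > 10000 nM in this assay, at which 2 of the 3 values shown sit, and none of the three has a resolved number, so no order among them can be read. Compound 4 `CC(C)[C@H](NC(=O)c1ccc(Cl)cc1O)C(=O)Nc1ccc(Cl)cc1` differs from compound 2 by chloro in place of bromo on an aromatic carbon. Within the data shown here, with no measured step to lean on, the expectation for compound 4 is no movement beyond the scatter in this assay, the step that the limit leaves unreadable from compound 2 to compound 4 being essentially flat. Compound 4 is therefore estimated at 20000 nM, within 5000 nM to 80000 nM, most likely again reported as a limit.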

Compound 4, half-maximal inhibitory concentration: > 10000 nM
Compound 4: a limit, no number; the forecaster's own chance of this, stated with the estimate: 85%; the middle value does not contradict the limit.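

Compound 2 and compound 4 both stop at limits, so chloro in place of bromo gives no readable step. With no resolved value among the compounds shown, the effect of any change on the shared core remains open.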